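The source may hold more compounds than are shown below. What is called first, only, known or untested is meant among the compounds shown, and "the series" means these compounds.

In a functional assay on Ehrlich cells (Mus musculus) for cytotoxicity, read by trypan blue exclusion, with a stated time of 2 h, tested at 100 ug/mL (a lower number here means a weaker effect, a higher number a stronger effect of the compound at the concentration tested), compound 1 `N#CC1=C(N)N(c2ccc(S(N)(=O)=O)cc2)C2=C(C(=O)CCC2)C1c1ccc(Cl)cc1Cl` gives 95% and compound 2 `N#CC1=C(NC(=O)c2ccc([N+](=O)[O-])cc2)N(c2ccc(S(N)(=O)=O)cc2)C2=C(C(=O)CCC2)C1c1ccc(Cl)cc1Cl` gives 70%. Compound 3 `CN(C)c1ccc(/C=N/C2=C(C#N)C(c3ccc(Cl)cc3Cl)C3=C(CCCC3=O)N2c2ccc(S(N)(=O)=O)cc2)cc1` gives 40%, the lowest of the three numbers. Both measured steps that put a larger group on that double-bonded ring carbon weakened the effect: a number 55 percentage points lower from compound 1 to compound 3 (beyond the scatter) and a number 30 percentage points lower from compound 2 to compound 3 (beyond the scatter). Compound 4 `CN(C)c1ccc(/C=C/C=N/C2=C(C#N)C(c3ccc(Cl)cc3Cl)C3=C(CCCC3=O)N2c2ccc(S(N)(=O)=O)cc2)cc1` differs from compound 3 by 2-(4-(dimethylamino)phenyl)ethenyl in place of 4-(dimethylamino)phenyl on a carbon with a double bond to nitrogen. Going by the values given here, no measured step lengthens this group; the known steps only exchange the whole group, so they give little guide to such an extension. A change of this kind is expected to stay within the usual scatter. The estimate for compound 4 in this assay is therefore 38%, with a range from 18% to 60%. The expected step is a number 2 percentage points lower from compound 3 to compound 4 (within the scatter).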

Compound 4, a percentage reported as activity, at one concentration (the size of the read-out at that concentration, not a potency): 20%
Compound 4: middle estimate off by 18 percentage points, on the high side; the measured number falls inside the stated range.
By their numbers in this assay, from the lowest: compound 4; then compound 3; then compound 2; then compound 1.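

Keeping the aromatic ring and its dimethylamino group while extending 4-(dimethylamino)phenyl to 2-(4-(dimethylamino)phenyl)ethenyl still changes the result in this assay and gives a number 20 percentage points lower from compound 3 to compound 4 (beyond the scatter). Going by these compounds alone, the earlier steps exchanged the whole group, so this is the first sign that this position responds to an added ethenyl link alone. Nothing available explains the drop.

As far as these compounds go, it remains open whether an ethyl link would lower the number as the ethenyl link does. A methoxy group in place of dimethylamino is also an open case.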